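The source may report more compounds than this note shows. Statements on the series, on what has been measured and on what is new or still open speak of the compounds shown alone.

Half-lives in an ADME assay on microsomes from liver (Mus musculus, strain CD-1) for metabolic stability, read by LC-MS, with a stated time of 60 min, tested at 20 uM; a higher number here means that the compound lasts longer, a lower number that the compound disappears faster:
- compound 1 `COc1cccc(C(C)Sc2nc3c(cnn3C)c(=O)n2-c2ccccc2)c1`: 0.1 h
- compound 2 `CC(Sc1nc2c(cnn2C)c(=O)n1-c1ccccc1)c1cncnc1`: 0.133 h

Compound 2, at 0.133 h, lies within the scatter of compound 1, at 0.1 h, so the two cannot be ranked.

The next compound to be read is compound 3 `CC(Sc1nc2c(cnn2C)c(=O)n1-c1ccccc1)c1ccccc1`. It carries phenyl in place of pyrimidin-5-yl on a saturated chain carbon bound to a saturated chain carbon and a sulfur.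

Going by the values given here, one measured step bears on this change. It is a 1.3-fold higher number from compound 1 to compound 2 (0.12 log units; within the scatter), made at the same place, and it stays within the scatter. Compound 1, with its 3-methoxyphenyl, already has a six-membered aromatic ring of carbon only at that place, and its value is 0.1 h. A single small step is thin evidence, but it gives no ground for expecting a step beyond the scatter in this assay, nor for a firm direction.

The expected step is a 1.2-fold lower number from compound 2 to compound 3 (0.08 log units; within the scatter), which would lie within the scatter. For compound 3 the estimated half-life is 0.11 h, with an expected range from 0.055 h to 0.22 h.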

Compound 3, half-life: 0.133 h
For compound 3 the middle estimate is 1.2-fold (0.08 log units) below the measured one, and the stated range covers the measured number.
By their numbers in this assay, from the lowest: compounds 1, 2 and 3 (each within the scatter of the next).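

In this assay, phenyl in place of pyrimidin-5-yl on a saturated chain carbon bound to a saturated chain carbon and a sulfur gives no change at the digits printed from compound 2 to compound 3 (within the scatter), so exchanging the ring nitrogens of pyrimidin-5-yl for carbon produces no readable step in this pair. The comparison with the methoxy-bearing ring gives a 1.3-fold higher number from compound 1 to compound 3 (0.12 log units; within the scatter), which shows that hydrogen in place of methoxy on an aromatic carbon also stays within the scatter, so compounds 1, 2 and 3 cannot be separated at this place. No supporting data bear on the reason for this flat reading.

The compounds shown carry only six-membered aromatic rings at this place, so it remains open whether a group of another kind there, such as a saturated ring carrying an amine or a ring bearing a carboxylic acid, would give a half-life beyond the scatter of these three. Going by these compounds, it also remains open whether a change elsewhere, such as a longer chain in place of the methyl on the saturated chain carbon, would separate any compound from this group.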